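Same Methyl-to-Hydrogen Change Tried on a Second Core

The compounds below may be only part of what the source reports. "The series", "measured", "known", "first", "only" and "open" are said of these compounds alone.

Three compounds were measured in a functional assay on S1 cells (Homo sapiens) for cytotoxicity, read by MTT assay, with a stated time of 72 h; on this read-out higher numbers stand for weaker inhibition and lower numbers for stronger inhibition. Compound 1, `Cc1cc(/C=C/c2ccc(O)cc2)[nH]n1`, gives 32900 nM in this assay. Compound 2, `COc1ccc(/C=C/c2cc(C)n[nH]2)cc1`, gives 8400 nM in this assay. Compound 3, `COc1ccc(/C=C/C(=O)CC(C)=O)cc1`, gives 44600 nM in this assay.

Compound 2 and compound 1 differ in one place only: hydrogen in place of methyl on an oxygen on an aromatic ring. This change produced a 3.9-fold higher number from compound 2 to compound 1 (0.59 log units; beyond the scatter).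

Compound 3 shares its methoxy-bearing ring with compound 2 but carries a different core; the difference between the two cores is not broken down here. The numbers of compound 3 and compound 1 lie within the scatter of each other, while compound 2 gives a lower number than compound 3.

Compound 4, `CC(=O)CC(=O)/C=C/c1ccc(O)cc1`, has not yet been measured. It differs from compound 3 in exactly the same way that compound 1 differs from compound 2: hydrogen in place of methyl on an oxygen on an aromatic ring. The place of the change is the same in both pairs, so this counts as the same change carried onto a second core.

For the measured compounds named here, the expected step is a 2.7-fold higher number from compound 3 to compound 4 (0.43 log units; beyond the scatter), estimated because a 3.9-fold higher number from compound 2 to compound 1 (0.59 log units; beyond the scatter) is the only measured example of this change, and it points toward a higher number. The core of compound 3 is not the core of compound 2, so the size is uncertain. Compound 4 is estimated at 120000 nM, with a plausible range from 40000 nM to 300000 nM.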

Compound 4, half-maximal inhibitory concentration: 10600 nM
Beside the measured number, compound 4's estimate is 11-fold (1.05 log units) above it; measured number below the stated range.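

In this assay, going from methoxy to hydroxy on the second core gives a 4.2-fold lower number from compound 3 to compound 4 (0.62 log units; beyond the scatter), so the change does not keep its direction when carried from one core to the other. The two steps are similar in size but run in opposite directions, and the gap between them is larger than the scatter of two such steps would explain: the same change on two cores in this assay, a 3.9-fold higher number (0.59 log units; beyond the scatter) from compound 2 to compound 1 and a 4.2-fold lower number (0.62 log units; beyond the scatter) from compound 3 to compound 4, 16-fold (1.22 log units) apart, beyond the scatter of two such steps. This shows that, in this series, the step measured on one core could not be used to predict the step on the other, but it does not show which part of the cores is responsible, and one pair on each core gives no general rule for any further core.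

The compounds shown carry only methoxy or hydroxy on the aromatic ring, so it remains open how a longer chain on that oxygen, such as ethoxy, or an amine in place of the hydroxy group would behave on each of the two cores. Going by these compounds, it also remains open whether the two cores part ways only for this change or for other changes on the same ring as well.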